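This account rests on a few compounds, and the source may have more. Where it says the series, first, only, none or still open, it means among the compounds named here.

In a functional assay on K562 cells (Homo sapiens) for cytotoxicity, read by sulforhodamine B assay, with a stated time of 48 h (a higher number here means that more compound is tolerated, a lower number that less compound is tolerated), compound 2, with structure `ClCc1ccccc1Cn1cnc2c(Cl)nc(Cl)nc21`, gives 910 nM. Going by the values given here, that is the only plain number in this set. Compound 1, with structure `ClCc1ccc(Cn2cnc3c(Cl)ncnc32)cc1`, sits at a limit of the assay: in this assay compound 1 gives > 100000 nM, a limit rather than a measured number, as noted in the limit of > 100000 nM in this assay, at which 1 of the 2 values shown sits. Among the compounds with values here, compound 2 and compound 1 differ in more than one place, so their two values show only that one gives a number and the other a limit.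

Compound 3, with structure `ClCc1ccccc1Cn1cnc2c(Cl)ncnc21`, has not yet been measured in this assay. It differs from compound 2 in one place: hydrogen in place of chloro on an aromatic carbon. Only the chloro leaves, and nothing but a hydrogen enters. Because compound 1, which also lacks this chloro, reaches only the limit > 100000 nM in this assay, the step from compound 2 to compound 3 is expected to be a loss beyond the scatter. The expected step is a 16-fold higher number from compound 2 to compound 3 (1.22 log units; beyond the scatter). Compound 3 is therefore estimated at 15000 nM in this assay, within a range from 2000 nM to 100000 nM, with a real chance that only a limit is reported.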

Compound 3, concentration lethal to 50% of the cells: > 100000 nM
Compound 3: a limit, no number; the forecaster's own chance of this, stated with the estimate: 35%; at least 6.6-fold (0.82 log units) between middle value and limit.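

In this assay, going by these compounds alone, the single exchange of this chloro for hydrogen, on the aromatic carbon between two ring nitrogen atoms, gives an at least 100-fold higher number from compound 2 to compound 3 (2.04 log units; beyond the scatter). Going by these compounds, compound 3 stands at a limit and not at a number, so this step gives only the smallest size the change can have, and the true size stays unknown. This is the first comparison in the set that isolates one change, and it shows that this one chlorine atom separates a plain number from a limit; of the compounds shown, only compound 2 carries the chloro and gives a number, while the two without it share the same limit: the limit of > 100000 nM in this assay, at which 2 of the 3 values shown sit.

Still open, on these data alone, is whether another group on this carbon, such as an amine, a methoxy group or a fluoro, would keep a number like that of compound 2 or end at the limit as hydrogen does. Also open, as far as these compounds go, is whether this chloro would make the same difference on the core of compound 1, whose chloromethyl group sits at a different place.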